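Working notes: three weak measured compounds and one untested analogue

The compounds below may be only part of what the source reports. "The series", "measured", "known", "first", "only" and "open" are said of these compounds alone.

Measured so far in an assay on COS-7 cells for inhibition of patatin-like phospholipase domain-containing protein 2 (Mus musculus); on this read-out lower numbers stand for stronger inhibition and higher numbers for weaker inhibition:

compound 1, `CCOC(=O)c1cccc(-c2ccc(CN3CCCCC3)cc2)c1`, compound 1 gives 75000 nM
compound 2, `CCOC(=O)c1cccc(-c2ccc(CN(C)C)o2)c1`, compound 2 gives 190000 nM
compound 3, `CCOc1ccc(-c2cccc(S(=O)(=O)NC)c2)cc1`, compound 3 gives 200000 nM

All three numbers are high, so inhibition is weak throughout. Compound 3 gives the highest number of the three, but compound 2 lies within the usual scatter of it, so the two cannot be ordered. Compound 1 gives a number that is lower by more than the scatter, so compound 1 stands apart from compound 3 on this read-out.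

Compound 4, `CCOc1ccc(-c2cccc(NC(C)=O)c2)cc1`, has not been measured. It differs from compound 3 in one place: acetamido in place of methylsulfamoyl on an aromatic carbon. For the measured compounds named here, nothing measured so far carries acetamido, so no step of this kind is known. Both groups keep one hydrogen-bond donor, and the compounds carrying this core give weak numbers anyway, so the step is expected to stay within the scatter, with no direction favoured. For compound 4 the expected value in this assay is 200000 nM, with a range from 60000 nM to 600000 nM. The expected step is no change at the digits printed from compound 3 to compound 4 (within the scatter). Compound 3 stands at 200000 nM, so compound 4 is expected to be a weak inhibitor as well.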

Compound 4, half-maximal inhibitory concentration: 200000 nM
For compound 4 middle estimate and measured number coincide at the digits printed; low and high end bracket the measured number.
By their numbers in this assay, from the lowest: compound 1; then compounds 2, 3 and 4 (each within the scatter of the next).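

In this assay, for the compounds shown here, the only step known at this aromatic carbon reads no change at the digits printed from compound 3 to compound 4 (within the scatter), so methylsulfamoyl and acetamido cannot be told apart here on the shared core. The exchange removes the sulfur-bearing group in favour of one with fewer heavy atoms and one double bond fewer outside aromatic rings, yet the read-out stays within the scatter and both compounds remain weak inhibitors. No supporting evidence bears on this result, and no cause can be assigned to it.

Still open, from the compounds shown here alone, is what a primary amine, a carboxylic acid or a methoxy group would do on this same aromatic carbon, since both groups compared here keep a hydrogen-bond donor. Also open, going by these compounds, is whether any replacement at this carbon can move the number beyond the scatter at all.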